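The source may hold more compounds than are shown below. What is called first, only, known or untested is meant among the compounds shown, and "the series" means these compounds.

Measured compounds in a functional assay on H184B5F5/M10 cells (Homo sapiens) for antiproliferative activity, read by XTT assay, with a stated time of 72 h; on this read-out lower numbers stand for stronger inhibition and higher numbers for weaker inhibition:
Compound 1 `COc1ccc(-c2cc3ccccc3nc2/C=C/C(=O)c2ccccc2)cc1` gives 8560 nM.
Compound 2 `COc1ccc(-c2cc3ccccc3nc2/C=C/C(=O)c2ccc(F)cc2)cc1` gives > 10000 nM, which is a limit of the assay and not a number.
Compound 3 `COc1ccc(-c2cc3ccccc3nc2/C=C/C(=O)c2c(OC)cccc2OC)cc1` gives 4470 nM.

Compound 1 stands highest of the two numbers; its nearest neighbour is compound 3, with a 1.9-fold lower number from compound 1 to compound 3 (0.28 log units; within the scatter). Compound 2 sits at the limit of > 10000 nM in this assay, at which 1 of the 3 values shown sits, so the step of an at least 1.1-fold higher number from compound 1 to compound 2 (0.06 log units; that floor lies within the scatter) can only be given as a floor. From compound 2 to compound 3, an at least 2.2-fold lower number from compound 2 to compound 3 (0.34 log units; beyond the scatter).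

Compound 4 `COc1ccc(-c2cc3ccccc3nc2/C=C/C(=O)c2ccc([N+](=O)[O-])cc2)cc1` differs from compound 1 as follows: nitro in place of hydrogen on an aromatic carbon. Going by the values given here, the measured step that bears on it most directly is the one from compound 1 to compound 2, fluoro in place of hydrogen on an aromatic carbon, which gave an at least 1.1-fold higher number from compound 1 to compound 2 (0.06 log units; that floor lies within the scatter). Among the compounds with values here, that change at the same place did not lower the number, and the only step that lowered the number beyond the scatter involved 2,6-dimethoxyphenyl on the carbonyl carbon, which compound 4 does not carry. For compound 4 the step of a 1.1-fold higher number from compound 1 to compound 4 (0.05 log units; within the scatter) is therefore expected to stay within the scatter. Compound 4 is estimated at 9500 nM, with a range of 4000 nM to 20000 nM.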

Compound 4, half-maximal inhibitory concentration: 6100 nM
Compound 4: middle estimate off by 1.6-fold (0.19 log units), on the high side, within the range that was stated.
By their numbers in this assay, from the lowest: compounds 3, 4 and 1 (each within the scatter of the next). At a limit, above all of these: compound 2.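

In this assay, the change from phenyl to 4-nitrophenyl on the carbonyl gives a 1.4-fold lower number from compound 1 to compound 4 (0.15 log units; within the scatter), and the comparison with the 2,6-dimethoxyphenyl compound gives a 1.4-fold higher number from compound 3 to compound 4 (0.14 log units; within the scatter), so compounds 1, 3 and 4 cannot be told apart at this level of scatter. Nitro in place of fluoro at the same place gives an at least 1.6-fold lower number from compound 2 to compound 4 (0.21 log units; that floor lies within the scatter), a floor that does not establish a difference between the two groups. Compound 2 remains a limit of the assay and not a number: the limit of > 10000 nM in this assay, at which 1 of the 4 values shown sits.

Open, on these data alone, is whether an amine or a carboxylic acid at this place would move the number beyond the scatter from compound 1. Also open, as far as these compounds go, is what a hydroxyl in place of the methoxy group on the shared core would do.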